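Dibromosalicylanilide series: removing one bromo from compound 1

The source may hold more compounds than are shown below. What is called first, only, known or untested is meant among the compounds shown, and "the series" means these compounds.

Measured compounds:
compound 1 `O=C(Nc1cccc(Cl)c1)c1cc(Br)cc(Br)c1O`: > 100000 nM
compound 2 `O=C(Nc1ccccc1)c1cc(Br)cc(Br)c1O`: > 100000 nM

In an assay on isolated protein for inhibition of thiosulfate sulfurtransferase (Homo sapiens), with a stated time of 60 min, in the absence of a further agent (a lower number here means a stronger inhibitor, a higher number a weaker inhibitor), compound 1 gives > 100000 nM, which is a limit of the assay and not a number. Compound 2 likewise gives > 100000 nM, also a limit. The step that the two limits leave unreadable from compound 1 to compound 2 is thus not readable in either direction; both values sit at the same limit (the limit of > 100000 nM in this assay, at which 2 of the 2 values shown sit). Compound 1 therefore stands only as a limit, with nothing that places it relative to compound 2.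

Compound 3 `O=C(Nc1cccc(Cl)c1)c1cc(Br)ccc1O` differs from compound 1 by hydrogen in place of bromo on an aromatic carbon. Among the measured compounds shown here, no measured step of this kind exists; the sole measured step, a step that the two limits leave unreadable from compound 1 to compound 2, gives no usable size. With compound 1 at the limit (the limit of > 100000 nM in this assay, at which 2 of the 2 values shown sit), compound 3 is expected to return a limit as well, and the step that the limit leaves unreadable from compound 1 to compound 3 is estimated as none beyond the scatter. Compound 3 is therefore estimated at 200000 nM, in the range 50000 nM to 1000000 nM.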

Compound 3, half-maximal inhibitory concentration: > 100000 nM
Compound 3: no number, only a limit (the forecaster's own chance of this, stated with the estimate: 85%); the middle value is on the limit's open side.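

The step from compound 1 to compound 3 cannot be read, and neither compound gives a number: the limit of > 100000 nM in this assay, at which 3 of the 3 values shown sit.

The compounds shown leave open whether the chloro or bromo groups affect inhibition in this assay, and what change to the shared core would give a measurable value.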